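Amino for hydroxy on the stilbene-like arm of compound 1

A few compounds are considered here, and "the series" means these few. Any claim that something is new, unique, unknown or untested is made for them only; others in the source may bear on it.

Compound 1 `C=C(/C=C/c1ccc(OC)c(O)c1)c1cc(OC)c(OC)c(OC)c1` is the reference point of this pair. In a functional assay on PC-3 cells (Homo sapiens) for antiproliferative activity, read by MTT assay, with a stated time of 48 h (a higher number here means a weaker inhibitor, a lower number a stronger inhibitor), compound 1 gives 423 nM, the lower of the two numbers recorded so far. Among the compounds with values here, the only other measured member, compound 2 `CO/C=C(\C=C\c1ccc(OC)c(O)c1)c1cc(OC)c(OC)c(OC)c1`, carries a methoxy on the exocyclic alkene instead of the terminal methylene; in this assay compound 2 gives 5330 nM, which stands well beyond the scatter from compound 1.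

The step now under consideration keeps the shared core of compound 1 unchanged and alters only one substituent: amino in place of hydroxy on an aromatic carbon, giving compound 3 `C=C(/C=C/c1ccc(OC)c(N)c1)c1cc(OC)c(OC)c(OC)c1`. The group that leaves and the group that enters each bring one heavy atom, one hydrogen-bond donor and one hydrogen-bond acceptor, at the same aromatic carbon, ortho to a methoxy group and meta to a large group.

Within the data shown here, no measured pair isolates this exchange, so the expected size of the step from compound 1 to compound 3 in this assay, a 1.4-fold lower number from compound 1 to compound 3 (0.15 log units; within the scatter), rests on the reference alone and is expected to be small, within or near the scatter. Compound 3 is accordingly estimated at 300 nM, with a range from 80 nM to 1500 nM.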

Compound 3, half-maximal inhibitory concentration: 560 nM
Beside the measured number, compound 3's estimate is 1.9-fold (0.27 log units) below it; the range from low to high includes it.
By their numbers in this assay, from the lowest: compounds 1 and 3 (each within the scatter of the next); then compound 2.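

In this assay, within the data shown here, amino in place of hydroxy on an aromatic carbon, ortho to a methoxy group and meta to a large group, gives a 1.3-fold higher number from compound 1 to compound 3 (0.12 log units; within the scatter), the first step that isolates a change at this carbon. Among these compounds, the earlier pair spoke only to the exocyclic alkene, where compound 1 and compound 2 stand well apart; this step shows that hydroxy is not the only group at the aromatic carbon compatible with a value in the range of compound 1. The data on hand offer no explanation for this outcome.

Still open, on these data alone, is how far this holds for other groups at the same carbon: fluorine, an acetamide, a carboxylic acid or plain hydrogen in place of hydroxy would show whether the group there matters at all for the read-out. Also open, as far as these compounds go, is whether amino would give a similar result with the methoxy-bearing exocyclic alkene of compound 2 in place of the terminal methylene.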